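Replacing Ethylamino with Cyclopropyl(methyl)amino on a Purine-Type Core

The source may hold more compounds than are shown below. What is called first, only, known or untested is meant among the compounds shown, and "the series" means these compounds.

Measured compounds:
- compound 1, `CNc1ncnc2c1ncn2Cc1c(F)cccc1F`: 2 mg/kg
- compound 2, `CNc1ncnc2c1ncn2Cc1cccc(F)c1F`: 18 mg/kg
- compound 3, `CCNc1ncnc2c1ncn2Cc1ccccc1F`: 4.9 mg/kg

In a functional assay on the whole organism with Rattus norvegicus as the target, in the maximal electroshock model (on this read-out lower numbers stand for an effect already at smaller amounts and higher numbers for an effect only at larger amounts of compound), compound 3 stands second highest of the three numbers, with compound 1 a clearly lower number and compound 2 a clearly higher one, both gaps beyond the scatter.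

Compound 4 is `CN(c1ncnc2c1ncn2Cc1ccccc1F)C1CC1`, not yet measured. It differs from compound 3 in one place: cyclopropyl(methyl)amino in place of ethylamino on an aromatic carbon. Within the data shown here, no measured pair shows this particular exchange, so its effect is unknown from the data.

A modest rise in dose is expected, with the step from compound 3 to compound 4 estimated at a 1.6-fold higher number from compound 3 to compound 4 (0.21 log units; within the scatter), near the edge of the scatter. For compound 4 the estimated value in this assay is 8 mg/kg, within 3 mg/kg to 25 mg/kg.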

Compound 4, dose for half-maximal effect: 6.8 mg/kg
The estimate for compound 4 lay 1.2-fold (0.07 log units) above the measured number; the measured number falls inside the stated range.
By their numbers in this assay, from the lowest: compound 1; then compounds 3 and 4 (each within the scatter of the next); then compound 2.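

In this assay, exchanging ethylamino for cyclopropyl(methyl)amino on this aromatic carbon gives a 1.4-fold higher number from compound 3 to compound 4 (0.14 log units; within the scatter). In this one pair, the position accepts the larger group, with its three-membered ring and no hydrogen-bond donor, without a change beyond the scatter. No supporting measurement offers an explanation for this result. As far as these compounds go, the exchange adds the ring and the methyl on the nitrogen together, so their separate contributions stay open. From the compounds shown here alone, how an unsubstituted amine or a longer chain would fare at this position also remains unknown.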